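Methyl in Place of Hydrogen: An Expected Step

The source may report more compounds than this note shows. Statements on the series, on what has been measured and on what is new or still open speak of the compounds shown alone.

Compound 1 `NC(=S)N/N=C1/CCCc2cccnc21` is tested in a toxicity assay on the whole organism (P388 cells, strain CDF1) for cytotoxicity, with Mus musculus as the target, with stated times of 6 days and 24 h, at a dose of 5 mg/kg (on this read-out lower numbers stand for a stronger effect and higher numbers for a weaker effect at the one dose given), where compound 1 gives 6.7%. Compound 2 `NC(=S)N/N=C1\CCCc2cccnc21` gives -3.8% in this assay; the step of a number 10.5 percentage points lower from compound 1 to compound 2 (beyond the scatter) rests on (the fact that compounds 1 and 2 differ only in the configuration as drawn). Compound 1 thus holds the higher of the two numbers. Compound 3 `CNC(=S)N/N=C1/CCCc2cccnc21` differs from compound 1 by methyl in place of hydrogen on an amide-type nitrogen. Among the compounds with values here, no measured step changes a group in this way; the only known step concerns a drawn configuration and does not bear on this change. No step beyond the scatter is therefore expected. Compound 3 is expected to give 7%, ranging from -10% to 25%. For compound 3 this means an estimated step of a number 0.3 percentage points higher from compound 1 to compound 3 (within the scatter).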

Compound 3, a percentage reported as activity, at one dose (the size of the read-out at that dose, not a potency): -7.7%
Compound 3: the middle estimate sits 14.7 percentage points above what was measured, within the range that was stated.
By their numbers in this assay, from the lowest: compounds 3 and 2 (each within the scatter of the next); then compound 1.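

In this assay, methyl in place of hydrogen on this amide-type nitrogen gives a number 14.4 percentage points lower from compound 1 to compound 3 (beyond the scatter). This shows that the position is sensitive: a single added carbon next to nothing else changed moves the read-out towards a stronger effect at the one dose given. Nothing known here accounts for this step.

The compounds shown leave open whether an ethyl group, a longer chain or a phenyl ring on this nitrogen would shift the number further. They also leave open whether methyl brings a similar step in the configuration drawn in compound 2.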